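Swapping the aryl group on the triazole of a triterpene ester

This account rests on a few compounds, and the source may have more. Where it says the series, first, only, none or still open, it means among the compounds named here.

Compound 1 `C/C(=C\CC/C(C)=C/CC[C@@H]1[C@@]2(C)CCC(=O)C(C)(C)[C@H]2CC[C@@]1(C)O)CC/C=C(\C)C(=O)OCc1cn(-c2ccc(F)cc2)nn1` in a functional assay on DU-145 cells (Homo sapiens) for antiproliferative activity, read by MTT assay, with a stated time of 48 h (on this read-out lower numbers stand for stronger inhibition and higher numbers for weaker inhibition), gives > 150000 nM, which is a limit of the assay rather than a number. Compound 2 `C/C(=C\CC/C(C)=C/CC[C@@H]1[C@@]2(C)CCC(=O)C(C)(C)[C@H]2CC[C@@]1(C)O)CC/C=C(\C)C(=O)OCc1cn(-c2ccc([N+](=O)[O-])cc2)nn1` gives in this assay > 150000 nM, again a limit. Compound 3 `C/C(=C\CC/C(C)=C/CC[C@@H]1[C@@]2(C)CCC(=O)C(C)(C)[C@H]2CC[C@@]1(C)O)CC/C=C(\C)C(=O)OCc1cn(-c2cccc(F)c2)nn1` gives in this assay > 150000 nM, also a limit.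

Compound 2 thus stands at the same limit as its two neighbours, as the limit of > 150000 nM in this assay, at which 3 of the 3 values shown sit, shows. Compound 4 `C/C(=C\CC/C(C)=C/CC[C@@H]1[C@@]2(C)CCC(=O)C(C)(C)[C@H]2CC[C@@]1(C)O)CC/C=C(\C)C(=O)OCc1cn(-c2cccc(O)c2)nn1` differs from it at the aromatic nitrogen: 3-hydroxyphenyl in place of 4-nitrophenyl on an aromatic nitrogen. Within the data shown here, the steps that bear on this position, a step that the two limits leave unreadable from compound 1 to compound 2 and a step that the two limits leave unreadable from compound 2 to compound 3, are both unreadable, since each ends at the limit. No direction can be expected from them. Compound 4 is therefore estimated at 150000 nM (range 60000 nM to 400000 nM), with the step of a number no higher from compound 2 to compound 4 (the limit leaves the size open) expected to be flat and most likely a limit again.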

Compound 4, half-maximal inhibitory concentration: 28400 nM
Compound 4: middle estimate off by 5.3-fold (0.72 log units), on the high side; measured number outside the range, below it.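

In this assay, this position proves able to move the read-out: 3-hydroxyphenyl on the aromatic nitrogen gives an at least 5.2-fold lower number from compound 2 to compound 4 (0.72 log units; beyond the scatter) and an at least 5.2-fold lower number from compound 1 to compound 4 (0.72 log units; beyond the scatter). A change at a single atom gives an at least 5.2-fold lower number from compound 3 to compound 4 (0.72 log units; beyond the scatter). Compound 4 alone has left the limit that the others share: the limit of > 150000 nM in this assay, at which 3 of the 4 values shown sit.

The steps among compound 1, compound 2 and compound 3 still cannot be read. As far as these compounds go, whether an amine or a carboxylic acid in place of the hydroxy would also leave the limit stays open.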